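Trading a long alkyl chain for an aryl sulfonamide

This account rests on a few compounds, and the source may have more. Where it says the series, first, only, none or still open, it means among the compounds named here.

- Compound 1 `COc1ccccc1-c1cn(C[C@H](O)[C@H]2OC(=O)C(OCc3ccccc3)=C2OCc2ccccc2)nn1`: > 100000 nM (a limit of the assay, not a number)
- Compound 2 `CCCCCCCCCCc1cn(C[C@H](O)[C@H]2OC(=O)C(OCc3ccccc3)=C2OCc2ccccc2)nn1`: 80 nM

Within the data shown here, in a functional assay on MCF7 cells (Homo sapiens) for antiproliferative activity, read by MTT assay, with a stated time of 72 h (on this read-out higher numbers stand for weaker inhibition and lower numbers for stronger inhibition), compound 2 gives 80 nM, the only true number so far. Compound 1 is known only by its limit, > 100000 nM.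

Compound 3 `O=C1O[C@H]([C@@H](O)Cn2cc(CNS(=O)(=O)c3ccc(Cl)cc3F)nn2)C(OCc2ccccc2)=C1OCc1ccccc1` has not yet been measured. It carries ((4-chloro-2-fluorophenyl)sulfonyl)amino in place of the nonyl of compound 2, on a saturated chain carbon bound to an aromatic carbon (((4-chloro-2-fluorophenyl)sulfonyl)amino in place of nonyl on a saturated chain carbon bound to an aromatic carbon).

Among the measured compounds shown here, only one measured step bears on this change: an at least 1200-fold lower number from compound 1 to compound 2 (3.09 log units; beyond the scatter). There, decyl took the place of 2-methoxyphenyl on an aromatic carbon. Compound 3 likewise lacks the long chain and has an aromatic ring in its new group, so part of that large step may be expected to reverse in this assay. The guide is thin, since the ring sits at a different place than in compound 1 and a single step sets the trend.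

A large move towards a higher number, meaning weaker inhibition, is therefore expected. The estimated step is a 190-fold higher number from compound 2 to compound 3 (2.27 log units; beyond the scatter). For compound 3 the expected value is 15000 nM, with an estimated range of 1500 nM to 100000 nM.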

Compound 3, half-maximal inhibitory concentration: 3390 nM
Compound 3: the middle estimate sits 4.4-fold (0.65 log units) above what was measured; the measured number falls inside the stated range.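

In this assay, the long chain proves not to be essential for a real reading at this position: compound 3, which has no nonyl group and carries ((4-chloro-2-fluorophenyl)sulfonyl)amino instead, gives 3390 nM. The change still has a large cost, a 42-fold higher number from compound 2 to compound 3 (1.63 log units; beyond the scatter), so an aromatic group attached through this sulfonyl-amino link, on a saturated chain carbon bound to an aromatic carbon, retains only part of the inhibition seen with the nonyl group. Of the three compounds, only compound 1 is known by a limit rather than a number: the limit of > 100000 nM in this assay, at which 1 of the 3 values shown sits.

The exchange removes a whole chain and brings in a ring, a sulfonyl group, an amino hydrogen and two halogens at once, so the compounds shown cannot tell which of these parts accounts for the step. A shorter chain such as butyl, a plain benzenesulfonyl group without chlorine or fluorine, or a simple amide in the same place would be needed to separate the loss of the chain from the effect of what replaced it.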